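A few compounds are considered here, and "the series" means these few. Any claim that something is new, unique, unknown or untested is made for them only; others in the source may bear on it.

Series notes. Compound 3 `O=C(Nc1ccccc1-c1ccccc1)[C@@H]1CCCN1C(=O)CCc1nc2ccccc2[nH]1` carries a phenyl on the aryl amide; in an assay on CHO cells for displacement of a labelled ligand from Orexin receptor type 2 (Homo sapiens) (a lower number here means a stronger inhibitor, a higher number a weaker inhibitor), compound 3 gives 6 nM, the highest number among the three measured compounds. Among the compounds with values here, compound 2 `COc1ccccc1-c1ccccc1NC(=O)[C@@H]1CCCN1C(=O)CCc1nc2ccccc2[nH]1` gives 2 nM in this assay, and the only single-point step within the set, a 3.0-fold higher number from compound 2 to compound 3 (0.48 log units; beyond the scatter), is the loss of the methoxy group. Within the data shown here, compound 1 `Cc1ccc2[nH]c(SCC(=O)N3CCC[C@H]3C(=O)Nc3ccccc3-n3cccc3)nc2c1`, with a 1H-pyrrol-1-yl on the aryl amide and a different linker, gives 0.2 nM; no single step connects it to compound 3, so the two values only show that a 1H-pyrrol-1-yl amide is compatible with a low number in this assay. Compound 4 `O=C(Nc1ccccc1-n1cccc1)[C@@H]1CCCN1C(=O)CCc1nc2ccccc2[nH]1` differs from compound 3 by 1H-pyrrol-1-yl in place of phenyl on an aromatic carbon. Among the measured compounds shown here, no measured step covers this exchange directly. The value of compound 1, 0.2 nM, argues against a rise in the number. The step from compound 3 to compound 4 is therefore expected to be modest and downward, a 2.0-fold lower number from compound 3 to compound 4 (0.30 log units; within the scatter). For compound 4 the estimate in this assay is 3 nM, with a range of 0.8 nM to 12 nM.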

Compound 4, inhibition constant: 11 nM
Estimate against measurement, compound 4: 3.7-fold (0.56 log units) below; the measured number falls inside the stated range.
By their numbers in this assay, from the lowest: compound 1; then compound 2; then compounds 3 and 4 (each within the scatter of the next).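

In this assay, a 1.8-fold higher number from compound 3 to compound 4 (0.26 log units; within the scatter) shows that 1H-pyrrol-1-yl and phenyl on this aromatic carbon are not separated, even though the exchange changes ring size and brings in a nitrogen. Measured against 2-methoxyphenyl, 1H-pyrrol-1-yl gives a 5.5-fold higher number from compound 2 to compound 4 (0.74 log units; beyond the scatter), so of the three groups at this place only 2-methoxyphenyl stands apart. With 1H-pyrrol-1-yl held constant, the large step of a 55-fold higher number from compound 1 to compound 4 (1.74 log units; beyond the scatter) lies entirely in the other place, where (1H-benzimidazol-2-yl)methyl replaces (5-methyl-1H-benzimidazol-2-yl)sulfanyl, and no measurement here accounts for any of these steps.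

That one step does not separate the methyl from the sulfanyl exchange. Going by these compounds, how a fluorine or an amine on the 1H-pyrrol-1-yl ring would read in this assay also remains open.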